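A few compounds are considered here, and "the series" means these few. Any claim that something is new, unique, unknown or untested is made for them only; others in the source may bear on it.

Values in a functional assay on SK-N-SH cells (Homo sapiens) for inhibition, read by MTT assay, with a stated time of 72 h, tested at 30 uM (on this read-out higher numbers stand for more inhibition of growth at the one concentration tested and lower numbers for less inhibition of growth), for the three measured compounds
Compound 1 `C=CCc1ccc(OCc2cn(-c3cccc([N+](=O)[O-])c3)nn2)c(O)c1` gives 31.1%
Compound 2 `C=CCc1cc(O)c(O)c(CN2CCC(CCO)CC2)c1` gives 15.3%
Compound 3 `C=CCc1ccc(OCc2cn(-c3ccc(C#N)cc3)nn2)c(O)c1` gives 37.5%

Compound 3 (37.5%) lies within the scatter of compound 1 (31.1%), and the two cannot be separated on these numbers. Its gap to compound 2 (15.3%) goes beyond the scatter, so compound 3 stands in the upper group of this small set.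

Compound 4 `C=CCc1ccc(OCc2cn(-c3ccccc3CO)nn2)c(O)c1` has 2-(hydroxymethyl)phenyl in place of 4-cyanophenyl on an aromatic nitrogen. Among the compounds with values here, no measured pair of compounds isolates this change, so any expectation in this assay is loose. Compound 1 (31.1%) also carries a different group on that nitrogen and stays within the scatter of compound 3, which suggests only a modest shift. A small fall that stays within the scatter is expected (a number 7.5 percentage points lower from compound 3 to compound 4 (within the scatter)). The estimated value for compound 4 is 30%, with an expected range from 15% to 45%.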

Compound 4, percent growth inhibition at one concentration: 12.9%
Beside the measured number, compound 4's estimate is 17.1 percentage points above it; the measured number lies below the stated range.
By their numbers in this assay, from the lowest: compounds 4 and 2 (each within the scatter of the next); then compounds 1 and 3 (each within the scatter of the next).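

Within the data shown here, the step gives the first comparison in this assay that isolates one place: with 2-(hydroxymethyl)phenyl in place of 4-cyanophenyl on the aromatic nitrogen and the rest of the structure kept, there is a number 24.6 percentage points lower from compound 3 to compound 4 (beyond the scatter). This position is therefore sensitive to the group it carries, even though both groups have 8 heavy atoms and one six-membered aromatic ring of carbon only. No measurement shown here bears on the reason for this fall.

The change swaps the nitrile for hydroxymethyl and also alters where the substituent stands on the phenyl ring, so the compounds shown do not say which of the two matters. A 4-(hydroxymethyl)phenyl or 2-cyanophenyl group on the same nitrogen would separate these two changes.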